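Swapping pyridin-4-yl for 3-methoxyphenyl on the shared core

A few compounds are considered here, and "the series" means these few. Any claim that something is new, unique, unknown or untested is made for them only; others in the source may bear on it.

In a functional assay on FM3A cells (Mus musculus) for antiproliferative activity (on this read-out lower numbers stand for stronger inhibition and higher numbers for weaker inhibition), compound 1 `COc1cc(C(=O)c2sc(-c3ccccc3)cc2N)cc(OC)c1OC` gives 13 nM and compound 2 `COc1cc(C(=O)c2sc(-c3ccncc3)cc2N)cc(OC)c1OC` gives 150 nM, the higher of the two numbers. Compound 3 `COc1cccc(-c2cc(N)c(C(=O)c3cc(OC)c(OC)c(OC)c3)s2)c1` is not yet measured. It differs from compound 2 by 3-methoxyphenyl in place of pyridin-4-yl on an aromatic carbon, with 3-methoxyphenyl in place of pyridin-4-yl on an aromatic carbon. Among the compounds with values here, the only measured step at this place is a 12-fold higher number from compound 1 to compound 2 (1.06 log units; beyond the scatter), where pyridin-4-yl replaced phenyl. Within the data shown here, compound 3 regains a ring of carbon only, but no measured compound shows what its methoxy adds, so only a partial return is expected. The estimated change is a 3.8-fold lower number from compound 2 to compound 3 (0.57 log units; beyond the scatter). Compound 3 is expected at 40 nM, within 10 nM to 150 nM.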

Compound 3, half-maximal inhibitory concentration: 36 nM
For compound 3 the middle estimate is 1.1-fold (0.05 log units) above the measured one; the range from low to high includes it.
By their numbers in this assay, from the lowest: compound 1; then compound 3; then compound 2.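

In this assay, 3-methoxyphenyl recovers part of what pyridin-4-yl lost on this aromatic carbon next to the ring sulfur, with a 4.2-fold lower number from compound 2 to compound 3 (0.62 log units; beyond the scatter). The recovery is incomplete: placing methoxy on the phenyl ring of compound 1 gives a 2.8-fold higher number from compound 1 to compound 3 (0.44 log units; beyond the scatter), so this position responds to a substituent on the phenyl ring as well as to the ring nitrogen of pyridin-4-yl. Going by these compounds, whether a hydroxy group or an amine in place of that methoxy would move the number further remains open. Nothing available gives a reason for either step.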